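The compounds below may be only part of what the source reports. "The series", "measured", "known", "first", "only" and "open" are said of these compounds alone.

Measured so far:
- compound 1, `CN(C)c1ccc2cc(NC(=O)CCc3ccc(C(F)(F)F)cc3)ccc2n1`: 110 nM
- compound 2, `O=C(CCc1ccc(C(F)(F)F)cc1)Nc1ccc2nc(N3CCCC3)ccc2c1`: 320 nM; 320 nM (2 entries)

Within the data shown here, in a functional assay on HEK293 cells for activation of melanin-concentrating hormone receptor 1 (Rattus norvegicus), read by inositol phosphate accumulation (a lower number here means that less compound is needed, a higher number that more compound is needed for the effect), compound 1 gives 110 nM, and this is the only number on hand for it. Compound 2 gives 320 nM; 320 nM (2 entries) in this assay, a value recorded twice with the same result. Among the measured compounds shown here, no step between the two has been worked out, so the pair says only what its two values show.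

Compound 3, `CCN(CC)c1ccc2cc(NC(=O)CCc3ccc(C(F)(F)F)cc3)ccc2n1`, is not yet measured. It differs from compound 1 in one place: diethylamino in place of dimethylamino on an aromatic carbon. For the measured compounds named here, the change is small, two carbons more on the same nitrogen, and nothing among the measured compounds isolates such a change. Compound 3 is therefore expected to stay close to compound 1, with a step of a 1.8-fold higher number from compound 1 to compound 3 (0.26 log units; within the scatter) that may fall within the scatter or lean slightly toward a higher value. The estimate for compound 3 in this assay is 200 nM, with a likely range from 80 nM to 500 nM.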

Compound 3, half-maximal effective concentration: 830 nM
Compound 3: the middle estimate sits 4.2-fold (0.62 log units) below what was measured; the whole stated range lies below it.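

At this position, on an aromatic carbon next to the ring nitrogen, the size of the amine substituent clearly matters. Putting diethylamino in place of dimethylamino in this assay gives a 7.5-fold higher number from compound 1 to compound 3 (0.88 log units; beyond the scatter) and so moves the number well past ordinary measurement noise, although the change adds only two carbons to the same nitrogen and leaves the hydrogen-bond donor and acceptor counts and the net charge as they were. Nothing on hand explains why such a small change has this effect.

On these data alone, whether the number would climb further with dipropylamino, or come back down with a plain amino group, remains open. How a morpholine ring would behave at this position is equally unknown, and a single step cannot establish a trend with chain length.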